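Sulfonyl aryl exchange: chlorophenyl to chloropyridinyl

A few compounds are considered here, and "the series" means these few. Any claim that something is new, unique, unknown or untested is made for them only; others in the source may bear on it.

The three measured compounds share one core and differ only at the nitrogen on the cyclohexane ring. Compound 1 `CCCN(CC[C@H]1CC[C@H](NC(=O)/C=C/c2ccc(Cl)cc2)CC1)[C@H]1CCc2nc(N)sc2C1` gives 2.5 nM in an assay on brain for displacement of a labelled ligand from D(3) dopamine receptor (Rattus norvegicus); on this read-out higher numbers stand for weaker inhibition and lower numbers for stronger inhibition. Compound 2 `CCCN(CC[C@H]1CC[C@H](NS(=O)(=O)c2cccc(Cl)c2)CC1)[C@H]1CCc2nc(N)sc2C1` gives 1.1 nM in this assay. Compound 3 `CCCN(CC[C@H]1CC[C@H](NS(=O)(=O)c2ccccc2Cl)CC1)[C@H]1CCc2nc(N)sc2C1` gives 0.68 nM in this assay. Compound 3 sits at the low end of the three numbers; the difference to compound 2 is within the scatter, whereas a 3.7-fold lower number from compound 1 to compound 3 (0.57 log units; beyond the scatter) is beyond it.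

Compound 4 `CCCN(CC[C@H]1CC[C@H](NS(=O)(=O)c2ccc(Cl)nc2)CC1)[C@H]1CCc2nc(N)sc2C1` carries 6-chloropyridin-3-yl in place of 2-chlorophenyl on a sulfonyl sulfur. Within the data shown here, no measured step exchanges the carbon ring for a ring with a hetero atom, so the change is only partly covered. Among the measured compounds shown here, the one step on the same sulfonyl sulfur, a 1.6-fold lower number from compound 2 to compound 3 (0.21 log units; within the scatter), shifts the chlorine within the ring and stays within the scatter; the other step at this nitrogen, a 2.3-fold lower number from compound 1 to compound 2 (0.36 log units; beyond the scatter), is modest. A small step, a 1.9-fold higher number from compound 3 to compound 4 (0.28 log units; within the scatter), towards a higher number in this assay is therefore expected for compound 4, not clearly beyond the scatter. Compound 4 is estimated at 1.3 nM, with a range from 0.4 nM to 4 nM.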

Compound 4, inhibition constant: 0.63 nM
The estimate for compound 4 lay 2.1-fold (0.31 log units) above the measured number, and the stated range covers the measured number.
By their numbers in this assay, from the lowest: compounds 4, 3 and 2 (each within the scatter of the next); then compound 1.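

In this assay, 6-chloropyridin-3-yl in place of 2-chlorophenyl on the sulfonyl sulfur gives a 1.1-fold lower number from compound 3 to compound 4 (0.03 log units; within the scatter), and the exchange for 3-chlorophenyl gives a 1.7-fold lower number from compound 2 to compound 4 (0.24 log units; within the scatter), so a ring with a hetero atom and a hydrogen-bond acceptor is tolerated at this place, with neither step distinguishable from the scatter. The step of a 4.0-fold lower number from compound 1 to compound 4 (0.60 log units; beyond the scatter) is beyond the scatter, as are the steps from compound 1 to compound 2 and compound 3, so compound 1 stands apart from all three sulfonyl compounds in this series. No evidence at hand bears on this result.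

Open, from the compounds shown here alone, is whether the chlorine matters on the pyridine ring: a pyridinyl group carrying an amine or a methoxy group instead could hold the number or lose it. Also open, going by these compounds, is how a chloropyridinyl group with the chlorine elsewhere on the ring would read.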